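Fluoro in place of hydrogen on compound 3

The compounds below may be only part of what the source reports. "The series", "measured", "known", "first", "only" and "open" are said of these compounds alone.

Compound 3 `C/C=C/C(=O)N(Cc1ccc(OC)cc1)c1cc(OC)c(OC)c(OC)c1` gives 500 nM in a functional assay on HCT-116 cells (Homo sapiens) for inhibition, read by MTT assay, with a stated time of 48 h (on this read-out lower numbers stand for stronger inhibition and higher numbers for weaker inhibition), and stands level with its nearest neighbour. That neighbour is compound 2 `C/C=C/C(=O)N(Cc1ccc(OC)c(N)c1)c1cc(OC)c(OC)c(OC)c1` at 300 nM and the step between them is a 1.7-fold higher number from compound 2 to compound 3 (0.22 log units; within the scatter) on the numbers. Far off lies compound 1 `C/C=C/C(=O)N(Cc1ccc(OC)c(OC)c1)c1cc(OC)c(OC)c(OC)c1` at 32800 nM with a step of a 66-fold lower number from compound 1 to compound 3 (1.82 log units; beyond the scatter) to reach the same point.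

Compound 4 `C/C=C/C(=O)N(Cc1ccc(OC)c(F)c1)c1cc(OC)c(OC)c(OC)c1` is new. The change is fluoro in place of hydrogen on an aromatic carbon and reads as fluoro in place of hydrogen on an aromatic carbon, ortho to a methoxy group and meta to a large group, turning 4-methoxyphenyl into 3-fluoro-4-methoxyphenyl.

The same carbon carries methoxy in compound 1 and amino in compound 2, so these steps bear directly on the change. Amino there made no difference beyond the scatter, while the move away from methoxy was large, with a 110-fold lower number from compound 1 to compound 2 (2.04 log units; beyond the scatter) as the second example. For the measured compounds named here, no measured compound carries fluoro, so the comparison remains indirect, and a loss like that of compound 1 cannot be ruled out.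

The step expected in this assay is a 1.3-fold higher number from compound 3 to compound 4 (0.11 log units; within the scatter) and this estimate stays within the scatter. The expected value for compound 4 is 650 nM with an estimated range from 150 nM to 3500 nM at this stage.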

Compound 4, half-maximal inhibitory concentration: 1160 nM
Estimate against measurement, compound 4: 1.8-fold (0.25 log units) below, within the range that was stated.
By their numbers in this assay, from the lowest: compounds 2 and 3 (each within the scatter of the next); then compound 4; then compound 1.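

In this assay, for the compounds shown here, fluoro is the first group on this carbon to read apart from hydrogen with the shared core otherwise unchanged and without a large loss: the step is a 2.3-fold higher number from compound 3 to compound 4 (0.37 log units; beyond the scatter), which is modest, whereas amino had stayed within the scatter of hydrogen. Fluoro also separates from amino at the same carbon, with a 3.9-fold higher number from compound 2 to compound 4 (0.59 log units; beyond the scatter), so this position does respond to a small change and not only to the large one seen with methoxy. Fluoro nevertheless remains far from methoxy, with a 28-fold lower number from compound 1 to compound 4 (1.45 log units; beyond the scatter), which places the four compounds in three tiers: hydrogen and amino together, then fluoro, then methoxy, so that the large loss seen with methoxy does not carry over to fluoro.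

Nothing presented here gives a reason for these differences. It remains open where chloro, hydroxy, methyl or ethoxy on this same carbon would fall among these tiers, and whether fluoro on another carbon of this ring, or a second fluoro, would give a step of similar size.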